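The compounds below may be only part of what the source reports. "The series", "measured", "known", "first", "only" and "open" are said of these compounds alone.

Measured compounds:
Compound 1, `COC1=CC(=O)C(=O)C(CCCCCCCCO)=C1OC`, gives 220 nM in an assay for inhibition of Polyunsaturated fatty acid 5-lipoxygenase (Homo sapiens), read by HPLC, with stated times of 15 min and 10 min; a lower number here means a stronger inhibitor, a higher number a weaker inhibitor.
Compound 2, `CCCCCCCCCCCCCc1c(O)c(O)cc(OC)c1OC`, gives 60 nM in this assay.

Of these two numbers, compound 2 has the lower one, so on this pair it is the stronger inhibitor; compound 1 stands a good way higher, and that gap lies beyond the usual scatter of repeated measurements. Compound 3, `CCCCCCCCCCCCCc1c(O)c(O)cc(OC)c1O`, has not yet been measured. It differs from compound 2 in a single place: hydrogen in place of methyl on an oxygen on an aromatic ring; cut one bond further out, the same difference reads methoxy to hydroxy. Among the compounds with values here, no pair of measured compounds shows this same change, so there is no measured step to lean on, and the expectation must rest on compound 2 alone. The expectation for compound 3 is therefore cautious: a modest step from compound 2, perhaps towards a somewhat lower number, but one that may well stay within the scatter. Compound 3 is expected to give about 45 nM in this assay, with a range from 15 nM to 150 nM. That estimate means a step of a 1.3-fold lower number from compound 2 to compound 3 (0.12 log units; within the scatter), stated as an expectation rather than a measurement.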

Compound 3, half-maximal inhibitory concentration: 290 nM
The estimate for compound 3 lay 6.4-fold (0.81 log units) below the measured number; the measured number lies above the stated range.
By their numbers in this assay, from the lowest: compound 2; then compounds 1 and 3 (each within the scatter of the next).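

In this assay, hydrogen in place of methyl on an oxygen on an aromatic ring gives a 4.8-fold higher number from compound 2 to compound 3 (0.68 log units; beyond the scatter), so here the methoxy compound is the stronger inhibitor and the hydroxy compound the weaker one. This single step shows that removing one carbon atom at this place is enough to move the number beyond the usual scatter, which a comparison of the two earlier compounds, differing in more than one place, could not show. The result records the size and direction of the change, but no measurement shown explains it.

From the compounds shown here alone, it remains open whether any departure from methoxy at this place would weaken inhibition, or whether a group such as ethoxy or an amine would keep the number near that of compound 2. Going by these compounds, the finding also rests on one pair sharing the same core and chain, so it remains unknown whether methoxy to hydroxy would give a similar step at the other methoxy group or on a compound with a shorter chain.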